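The source may hold more compounds than are shown below. What is called first, only, known or untested is meant among the compounds shown, and "the series" means these compounds.

Measured in an ADME assay on microsomes from liver (Rattus norvegicus) for metabolic stability, read by LC-MS, with a stated time of 30 min, tested at 1 uM; a higher number here means that more of the compound is left, a lower number that less of the compound is left:
- Compound 1 `CCNCc1cc(C)cc(Nc2nc3ccccc3n2Cc2ccc(C(F)(F)F)cc2)c1O`: 51%
- Compound 2 `CCNCc1cc(Cl)cc(Nc2nc3ccccc3n2Cc2ccc(C(F)(F)F)cc2)c1O`: 66%
- Compound 3 `CCNCc1cc(Cl)cc(Nc2nc3cc(F)c(F)cc3[nH]2)c1O`: > 99% (a limit of the assay, not a number)

Of the two readings that are numbers, compound 1 holds the lower. Among the measured compounds shown here, the gap to its only numerical neighbour is a number 15 percentage points higher from compound 1 to compound 2 (beyond the scatter).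

Compound 4 `CCN(CC)Cc1cc(C)cc(Nc2nc3ccccc3n2Cc2ccc(C(F)(F)F)cc2)c1O` keeps the core of compound 1 and turns ethylamino into diethylamino, with ethyl in place of hydrogen on an amine nitrogen. For the measured compounds named here, the single measured step is chloro in place of methyl on an aromatic carbon, so no measured step touches the amine nitrogen. That modest step serves only as a rough scale, and the direction here is a loose guess. The expected change is a number 6 percentage points lower from compound 1 to compound 4 (within the scatter). Compound 4 is estimated at 45%, with an expected range of 25% to 65%.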

Compound 4, percent of the compound remaining: < 7%
Compound 4 ended at the assay's limit; the forecaster's own chance of this, stated with the estimate: 2%; at least 38 percentage points between middle value and limit.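

In this assay, ethyl in place of hydrogen on the amine nitrogen gives a number at least 44 percentage points lower from compound 1 to compound 4 (beyond the scatter). Among the compounds shown here, the only earlier step, a number 15 percentage points higher from compound 1 to compound 2 (beyond the scatter), was modest and sat on an aromatic carbon, so this is the first reading at the amine nitrogen, and it shows that this position can move the result by a large amount. Compound 4 reads < 7%, a limit of the assay and not a number: the limit of < 7% in this assay, at which 1 of the 4 values shown sits.

The compounds shown leave open how far the true value of compound 4 lies past that limit. They also leave open whether a methyl group or a longer chain on this nitrogen would behave like ethyl, and whether the same change would hold with chloro in place of methyl.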